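This account rests on a few compounds, and the source may have more. Where it says the series, first, only, none or still open, it means among the compounds named here.

Compound 1 `COc1ccc(-c2c(C)nc3c(N4CC[C@@H](NC(C)=O)C4)cc(C)nn23)cc1OC` and compound 2 `COc1ccc(-c2c(C)nc3c(N4CC[C@@H](NC(=O)c5ccccc5)C4)cc(C)nn23)cc1OC` share one core and differ only in the group on a carbonyl carbon, phenyl in place of methyl. In an ADME assay on microsomes from liver (Homo sapiens) for metabolic stability, read by LC-MS, with NADPH named in the record, with a stated time of 60 min, tested at 1 uM, in the absence of a further agent (on this read-out lower numbers stand for a less stable compound and higher numbers for a more stable compound), compound 1 gives > 95%, which is a limit of the assay rather than a number. In this assay compound 2 also gives > 95%, again a limit. The step that the two limits leave unreadable from compound 1 to compound 2 is therefore unreadable, because both values sit at the limit of > 95% in this assay, at which 2 of the 2 values shown sit. Compound 3 `COc1ccc(-c2c(C)nc3c(N4CC[C@@H](NC(=O)COc5ccccc5)C4)cc(C)nn23)cc1OC` has not yet been measured; it differs from compound 2 by phenoxymethyl in place of phenyl on a carbonyl carbon. No measured step can be read in size, so no direction beyond the scatter is expected. Compound 2 stands at the limit, and compound 3 is expected to stay close to it, with an expected step of a number at least 5 percentage points lower from compound 2 to compound 3 (that floor lies within the scatter). For compound 3 the estimate in this assay is 90%, with a range from 72% to 99%.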

Compound 3, percent of the compound remaining: > 95%
Compound 3 was reported as a limit (the forecaster's own chance of this, stated with the estimate: 50%); at least 5 percentage points between middle value and limit.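

In this assay compound 3 gives > 95% as a limit of the assay and not a number. Neither its step from compound 1 nor its step from compound 2 can be read in size. From the compounds shown here alone, whether methyl, phenyl and phenoxymethyl on a carbonyl carbon differ at all in this assay remains open.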